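This account rests on a few compounds, and the source may have more. Where it says the series, first, only, none or still open, it means among the compounds named here.

Measured in an ADME assay on ECV-304 cells (Homo sapiens) for cytotoxicity, read by MTT assay, with a stated time of 72 h; a higher number here means a weaker inhibitor, a lower number a stronger inhibitor:
- compound 1 `COc1ccc(C2=C(c3cc(OC)c(OC)c(OC)c3)C(=O)CC2O[SiH2]C(C)(C)C)cc1`: > 100 ug/mL (a limit)
- compound 2 `COc1ccc(OC)c(C2=C(c3cc(OC)c(OC)c(OC)c3)C(=O)CC2O[SiH2]C(C)(C)C)c1`: 6.5 ug/mL
- compound 3 `COCOc1cc(C2=C(c3cc(OC)c(OC)c(OC)c3)C(=O)CC2O[SiH2]C(C)(C)C)ccc1OC`: 40 ug/mL

Compound 3 holds the higher of the two actual numbers, and compound 2 is its nearest neighbour, as a 6.2-fold higher number from compound 2 to compound 3 (0.79 log units; beyond the scatter) shows. Compound 4 `COc1cc(C2=C(c3cc(C)c(OC)c(C)c3)C(O[SiH2]C(C)(C)C)CC2=O)cc(OC)c1OC` carries 4-methoxy-3,5-dimethylphenyl in place of 4-methoxy-3-(methoxymethoxy)phenyl on a double-bonded ring carbon. Three measured changes to this aryl group bear on it: an at least 15-fold lower number from compound 1 to compound 2 (1.18 log units; beyond the scatter), an at least 2.5-fold lower number from compound 1 to compound 3 (0.39 log units; beyond the scatter) and a 6.2-fold higher number from compound 2 to compound 3 (0.79 log units; beyond the scatter). They differ in size and run both ways, so no firm direction follows, and only a small shift is expected. The expected step is a 1.3-fold lower number from compound 3 to compound 4 (0.12 log units; within the scatter). For compound 4 the estimated value is 30 ug/mL, with an expected range of 7 ug/mL to 100 ug/mL.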

Compound 4, half-maximal inhibitory concentration: 15 ug/mL
The estimate for compound 4 lay 2.0-fold (0.30 log units) above the measured number; the measured number falls inside the stated range.
By their numbers in this assay, from the lowest: compound 2; then compound 4; then compound 3. At a limit, above all of these: compound 1.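

In this assay, 4-methoxy-3,5-dimethylphenyl, which carries methyl groups and no methoxymethoxy, gives a 2.7-fold lower number from compound 3 to compound 4 (0.43 log units; beyond the scatter), so methoxymethoxy is not required at this place for a lower number. This group still does not match 2,5-dimethoxyphenyl, with a 2.3-fold higher number from compound 2 to compound 4 (0.36 log units; beyond the scatter). Compound 1 stands at a limit, so an at least 6.6-fold lower number from compound 1 to compound 4 (0.82 log units; beyond the scatter) is only a bound: the limit of > 100 ug/mL in this assay, at which 1 of the 4 values shown sits.

The compounds shown leave open how an amine or a carboxylic acid on this aryl group would read. They also leave open whether the methyl groups would give the same number without the methoxy group.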